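Ring Amides Versus Ethylamide on a Shared Core

The source may hold more compounds than are shown below. What is called first, only, known or untested is meant among the compounds shown, and "the series" means these compounds.

Of the compounds shown here, three sharing one core have been measured in a functional assay on A549 cells (Homo sapiens) for inhibition, read by MTT assay, with a stated time of 48 h; a lower number here means a stronger inhibitor, a higher number a weaker inhibitor. Compound 1 `COc1ccc(/C=C/c2cc(OC)cc(OC)c2/C=C/C(=O)N2CCCCC2)cc1` gives 10600 nM, compound 2 `COc1ccc(/C=C/c2cc(OC)cc(OC)c2/C=C/C(=O)N2CCCC2)cc1` gives 6350 nM, and compound 3 `CCNC(=O)/C=C/c1c(/C=C/c2ccc(OC)cc2)cc(OC)cc1OC` gives 7860 nM. All three values lie within the scatter of one another: a 1.7-fold lower number from compound 1 to compound 2 (0.22 log units; within the scatter), a 1.3-fold lower number from compound 1 to compound 3 (0.13 log units; within the scatter), and a 1.2-fold higher number from compound 2 to compound 3 (0.09 log units; within the scatter). Compound 3 therefore stands among neighbours it cannot be separated from, with compound 2 nearest and compound 1 furthest.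

Compound 4 `COc1ccc(/C=C/c2cc(OC)cc(OC)c2/C=C/C(=O)N2CCCC(C)C2)cc1` differs from compound 3 in one place: 3-methylpiperidin-1-yl in place of ethylamino on a carbonyl carbon. Going by the values given here, the steps that bear on this change are the exchanges between the ethylamino amide and the ring amides of compound 1 and compound 2, which were a 1.3-fold lower number from compound 1 to compound 3 (0.13 log units; within the scatter) and a 1.2-fold higher number from compound 2 to compound 3 (0.09 log units; within the scatter). Neither left the scatter, so a ring amide with one more methyl group is expected to give a step of a 1.1-fold higher number from compound 3 to compound 4 (0.06 log units; within the scatter), that is, none beyond the scatter. Compound 4 is accordingly estimated at 9000 nM in this assay, within the range 4000 nM to 20000 nM.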

Compound 4, half-maximal inhibitory concentration: 5820 nM
Estimate against measurement, compound 4: 1.5-fold (0.19 log units) above; the measured number falls inside the stated range.
By their numbers in this assay, from the lowest: compounds 4, 2, 3 and 1 (each within the scatter of the next).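

At the carbonyl carbon, 3-methylpiperidin-1-yl in place of ethylamino gives up the amide hydrogen, yet it yields a 1.4-fold lower number from compound 3 to compound 4 (0.13 log units; within the scatter) in this assay, and the same group in place of pyrrolidin-1-yl yields a 1.1-fold lower number from compound 2 to compound 4 (0.04 log units; within the scatter) in that assay. Methyl in place of hydrogen on a saturated ring carbon, a change the earlier compounds did not include, gives a 1.8-fold lower number from compound 1 to compound 4 (0.26 log units; within the scatter) and so adds a ring substituent without separating the two compounds, leaving all four amides on the shared core indistinguishable in this assay. No evidence on the basis of these values is available.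

Going by these compounds, whether a hydroxyl group, a primary amine or a carboxylic acid on the amide ring would move the number beyond the scatter remains open. So does the effect of a longer chain, such as n-butylamino, in place of ethylamino.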